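Methoxy to fluoro: what compound 4 may tolerate

The source may report more compounds than this note shows. Statements on the series, on what has been measured and on what is new or still open speak of the compounds shown alone.

Compound 1 `O=C(O)CCC(=O)Nc1ccc(-c2nc3cc(C(F)(F)F)ccc3[nH]2)cc1`: > 100000 nM
Compound 2 `CCC(=O)Nc1ccc(-c2nc3cc(C(F)(F)F)ccc3[nH]2)cc1`: > 100000 nM
Compound 3 `COc1ccc(-c2nc3cc(C(F)(F)F)ccc3[nH]2)cc1`: 15000 nM

In an ADME assay on Vero cells (Chlorocebus sabaeus) for cytotoxicity (a higher number here means that more compound is tolerated, a lower number that less compound is tolerated), compound 1 gives > 100000 nM, which is a limit of the assay rather than a number. Compound 2 likewise gives > 100000 nM, again a limit. Among the measured compounds shown here, compound 3 gives 15000 nM, the only actual number among the three, so it is the sole firm anchor.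

Compound 4 `Fc1ccc(-c2nc3cc(C(F)(F)F)ccc3[nH]2)cc1` differs from compound 3 by fluoro in place of methoxy on an aromatic carbon. For the measured compounds named here, no measured step swaps these two groups, so none bears on it directly. The steps reaching compound 3, an at least 6.6-fold lower number from compound 1 to compound 3 (0.82 log units; beyond the scatter) and an at least 6.6-fold lower number from compound 2 to compound 3 (0.82 log units; beyond the scatter), both start from the limit of > 100000 nM in this assay, at which 2 of the 3 values shown sit, and are at least modest, but they exchange long amide chains for a small group, not methoxy for fluoro. Compound 4 is therefore expected to stay close to compound 3, with an expected step of no change at the digits printed from compound 3 to compound 4 (within the scatter) in this assay that lies within the scatter. The estimate for compound 4 is 15000 nM, between 5000 nM and 45000 nM.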

Compound 4, half-maximal cytotoxic concentration: 60000 nM
Beside the measured number, compound 4's estimate is 4.0-fold (0.60 log units) below it, outside the stated range (above it).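

In this assay, among the compounds shown here, even a swap between two small groups on this aromatic carbon moves the result, which the long amide chains of the earlier compounds could not show: fluoro in place of methoxy gives a 4.0-fold higher number from compound 3 to compound 4 (0.60 log units; beyond the scatter). Against those amide compounds, fluoro reads only as an at least 1.6-fold lower number from compound 2 to compound 4 (0.22 log units; that floor lies within the scatter) and as an at least 1.6-fold lower number from compound 1 to compound 4 (0.22 log units; that floor lies within the scatter), so compound 4 cannot be firmly ranked against either. Both comparisons start from a limit rather than a number: the limit of > 100000 nM in this assay, at which 2 of the 4 values shown sit.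

As far as these compounds go, whether chloro, hydroxy or an amine on this carbon would sit nearer fluoro or methoxy stays open. So does whether the methoxy-to-fluoro step would hold on another core.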